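Sulfonamide nitrogen substituent swap: solubility notes on the series

The compounds below may be only part of what the source reports. "The series", "measured", "known", "first", "only" and "open" are said of these compounds alone.

Measured so far:
- Compound 1, `Cc1ncc([N+](=O)[O-])n1CCS(=O)(=O)NCCO`, gives > 49300000 nM in a physicochemical assay for solubility, read by HPLC (a higher number here means a more soluble compound, a lower number a less soluble compound), which is a limit of the assay rather than a number.
- Compound 2, `Cc1ncc([N+](=O)[O-])n1CCS(=O)(=O)NCCCN(C)C`, gives > 53800000 nM in this assay, again a limit.
- Compound 3, `CCN(CC)CCNS(=O)(=O)CCn1c([N+](=O)[O-])cnc1C`, gives 45700000 nM in this assay.

Among the compounds with values here, compound 2 stands at a limit in this assay; of the three values shown, one other is also a limit, and the one read number, that of compound 3, sits within the scatter of both floors. Compound 4, `Cc1ncc([N+](=O)[O-])n1CCS(=O)(=O)N1CCN(C)CC1`, is not yet measured. It differs from compound 2 as follows: 4-methylpiperazin-1-yl in place of (3-(dimethylamino)propyl)amino on a sulfonyl sulfur. The measured steps that touch the same sulfonamide region are a step that the two limits leave unreadable from compound 1 to compound 2 and an at least 1.1-fold lower number from compound 2 to compound 3 (0.07 log units; that floor lies within the scatter); neither shows a change beyond the scatter, and the third pair, an at least 1.0-fold lower number from compound 1 to compound 3 (0.03 log units; that floor lies within the scatter), likewise. No change beyond the scatter is therefore expected in this assay for the step to compound 4, though a limit may again be reported. Compound 4 is estimated at 45000000 nM, with a range from 20000000 nM to 60000000 nM. The expected step is an at least 1.1-fold lower number from compound 2 to compound 4 (0.07 log units; that floor lies within the scatter).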

Compound 4, solubility: 14500000 nM
Compound 4: the middle estimate sits 3.1-fold (0.49 log units) above what was measured; measured number outside the range, below it.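

In this assay, within the data shown here, swapping the group on the sulfonyl sulfur gives the first steps beyond the scatter: 4-methylpiperazin-1-yl in place of (3-(dimethylamino)propyl)amino gives an at least 3.7-fold lower number from compound 2 to compound 4 (0.56 log units; beyond the scatter), and 4-methylpiperazin-1-yl in place of (2-hydroxyethyl)amino gives an at least 3.4-fold lower number from compound 1 to compound 4 (0.53 log units; beyond the scatter). In the first of these steps the leaving and entering groups hold the same heavy atoms, so the step comes with a ring and the loss of the hydrogen-bond donor, not with a change in those atoms. Neither step is known beyond its floor, because the starting compound stands at a limit in each case, compound 2 among them: the limit of > 53800000 nM in this assay, at which 1 of the 4 values shown sits.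

The ring and the loss of the donor change together in compound 4, so the compounds shown cannot separate them. A methyl group on the sulfonamide nitrogen of compound 2 would remove the donor while keeping the open chain.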